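Methoxy Addition in a Hydroxamate Series Without Measurable Effect

The source may report more compounds than this note shows. Statements on the series, on what has been measured and on what is new or still open speak of the compounds shown alone.

Three hydroxamic acids were examined in a functional assay on HL-60 cells (Homo sapiens) for antiproliferative activity, tested at 20 uM; on this read-out lower numbers stand for a weaker effect and higher numbers for a stronger effect at the one concentration tested. Compound 1 `Cc1cc2cc(NS(=O)(=O)Cc3ccc(C(=O)NO)cc3)ccc2n(C)c1=O` gives 0% in this assay. Compound 3 `Cc1cc2cc(NS(=O)(=O)Cc3cccc(C(=O)NO)c3)ccc2n(C)c1=O` differs from compound 1 in a way that is not broken down here; in this assay compound 3 gives 0%. Compound 2 `COc1ccc(C(=O)NO)cc1CS(=O)(=O)Nc1ccc2c(c1)cc(C)c(=O)n2C` gives 0% in this assay. The change from compound 3 to compound 2, (methoxy in place of hydrogen on an aromatic carbon), produced no change at the digits printed from compound 3 to compound 2 (within the scatter). Compound 4 `COc1cc(C(=O)NO)ccc1CS(=O)(=O)Nc1ccc2c(c1)cc(C)c(=O)n2C` arises from compound 1 by the same kind of change, (methoxy in place of hydrogen on an aromatic carbon), though here the site is meta rather than para to the hydroxycarbamoyl group. Because the comparable change gave no change at the digits printed from compound 3 to compound 2 (within the scatter), compound 4 is expected to show no change at the digits printed from compound 1 to compound 4 (within the scatter) in this assay. Compound 4 is therefore estimated at 0%, between 0% and 10%.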

Compound 4, a percentage reported as inhibition, at one concentration (the size of the read-out at that concentration, not a potency): 0%
Beside the measured number, compound 4's estimate shows no gap at the digits printed, within the range that was stated.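

Methoxy in place of hydrogen on an aromatic carbon gave no change at the digits printed from compound 1 to compound 4 (within the scatter) in this assay. The change therefore reads alike on the two cores: the same change on two cores in this assay, no change at the digits printed (within the scatter) from compound 3 to compound 2 and no change at the digits printed (within the scatter) from compound 1 to compound 4, 0 percentage points apart, within the scatter of two such steps

Yet compound 4 gives 0%, as do the other three compounds, so this agreement shows only that methoxy produced no detectable inhibition on these cores; it does not show how methoxy would act on a compound with measurable inhibition in this assay.

The compounds shown leave open whether another group on this aromatic ring, such as fluorine, an amine or a longer alkoxy chain, would produce any inhibition. They also leave open how these four compounds would behave at a higher concentration.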